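A few compounds are considered here, and "the series" means these few. Any claim that something is new, unique, unknown or untested is made for them only; others in the source may bear on it.

Three measured compounds share one core and differ only in the group on an aromatic carbon of a six-membered aromatic ring of carbon only. In a functional assay on the whole organism (strain albino) with Mus musculus as the target, at a dose of 100 mg/kg by the intraperitoneal route (a lower number here means less inhibition, a higher number more inhibition at the dose given (going by the name of the read-out)), compound 1 `COc1ccc(NC(=O)Nn2c(-c3ccccc3)nc3ccccc3c2=O)cc1` gives 52%, compound 2 `O=C(Nc1ccccc1)Nn1c(-c2ccccc2)nc2ccccc2c1=O` gives 56% and compound 3 `CCc1ccc(NC(=O)Nn2c(-c3ccccc3)nc3ccccc3c2=O)cc1` gives 61%. Compound 3 stands highest of the three numbers, yet both of its steps are within the scatter: a number 9 percentage points higher from compound 1 to compound 3 (within the scatter) and a number 5 percentage points higher from compound 2 to compound 3 (within the scatter). Compound 4 `O=C(Nc1ccc(Cl)cc1)Nn1c(-c2ccccc2)nc2ccccc2c1=O` differs from compound 3 by chloro in place of ethyl on an aromatic carbon. Among the compounds with values here, no measured step involves chloro; the steps that exist, including a number 4 percentage points higher from compound 1 to compound 2 (within the scatter), all stayed within the scatter, so in this assay no step beyond the scatter is expected. Compound 4 is therefore estimated at 57%, with a range from 45% to 68%. The expected step is a number 4 percentage points lower from compound 3 to compound 4 (within the scatter).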

Compound 4, a percentage reported as inhibition, in the whole organism at one dose (the size of the read-out at that dose, not a potency): 55%
For compound 4 the middle estimate is 2 percentage points above the measured one; low and high end bracket the measured number.
By their numbers in this assay, from the lowest: compounds 1, 4, 2 and 3 (each within the scatter of the next).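

In this assay, chloro on the aromatic carbon para to a large group gives only steps within the scatter (a number 6 percentage points lower from compound 3 to compound 4 (within the scatter)), (a number 1 percentage points lower from compound 2 to compound 4 (within the scatter)) and (a number 3 percentage points higher from compound 1 to compound 4 (within the scatter)). Chloro, ethyl and methoxy at this place therefore cannot be told apart from hydrogen or from one another at this single dose. No evidence at hand bears on these results.

As far as these compounds go, whether an amine, a carboxylic acid or a longer chain at this place would give a step beyond the scatter stays open. So does whether any group here would matter at another dose.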